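Oral Bioavailability Across Three Pyridinone Ethers in Rat

The source may report more compounds than this note shows. Statements on the series, on what has been measured and on what is new or still open speak of the compounds shown alone.

The study compares two measured compounds and one that awaits measurement. Compound 1 `Cc1cc(OCc2ccc(F)cc2F)c(Br)c(=O)n1Cc1ccc(CN(C)C)cc1` gives 91% in an in vivo ADME assay on the whole organism (strain Sprague-Dawley) for pharmacokinetics, with Rattus norvegicus as the target; on this read-out lower numbers stand for lower oral bioavailability and higher numbers for higher oral bioavailability. Compound 2 `Cc1cnc(-n2c(C)cc(OCc3ccc(F)cc3F)c(Br)c2=O)cn1` gives 30% in this assay. Compound 1 therefore stands highest of the two numbers shown, and its gap to compound 2 lies beyond the scatter.

Compound 3 `Cc1cc(OCc2ccc(F)cc2F)c(Br)c(=O)n1Cc1ccc(CNC(=O)CO)cc1` differs from compound 1 in a single respect: ((hydroxymethyl)carbonyl)amino in place of dimethylamino on a saturated chain carbon bound to an aromatic carbon. Among the measured compounds shown here, no step between measured compounds shows what this kind of exchange does, so the expectation rests on compound 1 alone and on the structural change itself.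

The account expects a downward step from compound 1 to compound 3 in this assay, estimated as a number 36 percentage points lower from compound 1 to compound 3 (beyond the scatter), which would place it beyond the scatter rather than within it. For compound 3 the estimated value in this assay is 55%, with a range from 25% to 85%, because compound 1 sits at 91% and leaves little room for a rise.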

Compound 3, oral bioavailability: 33%
Estimate against measurement, compound 3: 22 percentage points above, and the stated range covers the measured number.
By their numbers in this assay, from the lowest: compounds 2 and 3 (each within the scatter of the next); then compound 1.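

In this assay, among the compounds shown here, the exchange of dimethylamino for ((hydroxymethyl)carbonyl)amino on a saturated chain carbon bound to an aromatic carbon gives a number 58 percentage points lower from compound 1 to compound 3 (beyond the scatter) as a large step, and it is the first step in the study that isolates a single place on the shared core. It shows that this position is not indifferent to the group it carries: with the rest of the structure held constant, this one exchange alone moves oral bioavailability well beyond the usual scatter. No measurement shown here bears on what lies behind the step, so the result fixes its size and direction and nothing more.

One step cannot separate the loss of dimethylamino from the arrival of ((hydroxymethyl)carbonyl)amino, so it remains open which of the two accounts for the fall. The compounds shown also leave open where other groups in this place would fall in this assay, such as a primary amine, a pyrrolidine, a carboxylic acid or a plain acetamide without the hydroxyl.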